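The source may hold more compounds than are shown below. What is called first, only, known or untested is meant among the compounds shown, and "the series" means these compounds.

Measured in a functional assay on SMMC-7721 cells (Homo sapiens) for inhibition, read by MTT assay, with a stated time of 48 h; a higher number here means a weaker inhibitor, a lower number a stronger inhibitor:
compound 1 `Nc1n[nH]c2cccc(-c3cccc(NC(=O)Nc4cccc(F)c4)c3)c12`, 1240 nM
compound 2 `Nc1n[nH]c2cccc(-c3cccc(NC(=O)Nc4ccc(F)c(F)c4)c3)c12`, 5880 nM
compound 3 `Nc1n[nH]c2cccc(-c3cccc(NC(=O)Nc4cc(C(F)(F)F)cc(C(F)(F)F)c4)c3)c12`, 3540 nM

Compound 1 has the lowest number of the three; compound 3 is nearest and compound 2 furthest, both beyond the scatter. Compound 4 `Nc1n[nH]c2cccc(-c3cccc(NC(=O)Nc4cccc(Cl)c4)c3)c12` is not yet measured. Its difference from compound 1: chloro in place of fluoro on an aromatic carbon.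

Going by the values given here, no measured step exchanges one halogen for another, so nothing bears directly on this change. Among the compounds with values here, the only single-place step, a 4.7-fold higher number from compound 1 to compound 2 (0.68 log units; beyond the scatter), adds a fluoro on an aromatic carbon and weakens inhibition modestly; it concerns a second substituent, not the exchange of the one already present. Within the data shown here, compound 3, carrying two trifluoromethyl groups, also sits higher than compound 1, but no single step connects them. With the substituent count unchanged, compound 4 is expected to show only a small step in this assay, in no firm direction and likely within the scatter, a 1.0-fold higher number from compound 1 to compound 4 (0.02 log units; within the scatter). Compound 4 is estimated at 1300 nM, range 550 nM to 3100 nM.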

Compound 4, half-maximal inhibitory concentration: 1830 nM
Estimate against measurement, compound 4: 1.4-fold (0.15 log units) below; low and high end bracket the measured number.
By their numbers in this assay, from the lowest: compounds 1, 4, 3 and 2 (each within the scatter of the next, the first and the last beyond it).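

In this assay the exchange of 3-fluorophenyl for 3-chlorophenyl gives a 1.5-fold higher number from compound 1 to compound 4 (0.17 log units; within the scatter) and so cannot be read as a change: on this aromatic carbon, meta to a large group, the two halogens are not told apart. The other new step, a 3.2-fold lower number from compound 2 to compound 4 (0.51 log units; beyond the scatter) for 3-chlorophenyl in place of 3,4-difluorophenyl, is beyond the scatter, so among these compounds the readable loss goes with the added fluoro of compound 2 and not with the halogen exchange. Nothing available gives a reason for either step.

From the compounds shown here alone, whether this tolerance extends to a larger halogen such as bromo, or to a methyl, methoxy or nitrile group in the same place, remains open. An amine or a carboxylic acid on this ring is equally untested by the compounds shown.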